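The compounds below may be only part of what the source reports. "The series", "measured", "known", "first", "only" and "open" are said of these compounds alone.

Compound 1 `CCCNCc1cccc(OCCCCCC(=O)OCC)c1` and compound 2 `CCCNCc1ccc(OCCCCCC(=O)OCC)cc1` are built from the same atoms joined differently; the difference between the two cores is not broken down here. In an ADME assay on HepG2 cells (Homo sapiens) for cytotoxicity, read by CellTiter-Glo and resazurin assay, with a stated time of 72 h (on this read-out lower numbers stand for an effect already at smaller amounts and higher numbers for an effect only at larger amounts of compound), compound 1 gives only an assay limit of > 26000 nM. In this assay compound 2 likewise gives only a limit of > 26000 nM. Compound 3 `CCOC(=O)CCCCCOc1cccc(C=O)c1` carries the change (formyl in place of (propylamino)methyl on an aromatic carbon). In this assay compound 3 again gives only a limit of > 26000 nM, and the step that the two limits leave unreadable from compound 1 to compound 3 cannot be sized because the limit of > 26000 nM in this assay, at which 3 of the 3 values shown sit, holds every value. Compound 4 `CCOC(=O)CCCCCOc1ccc(C=O)cc1` carries the same kind of change, (formyl in place of (propylamino)methyl on an aromatic carbon), with the place para to a large group rather than meta. Resting on a step that the two limits leave unreadable from compound 1 to compound 3 and on (the limit of > 26000 nM in this assay, at which 3 of the 3 values shown sit), the step that the limit leaves unreadable from compound 2 to compound 4 is expected to be small. Compound 4 is expected to give about 40000 nM, between 20000 nM and 100000 nM.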

Compound 4, half-maximal effective concentration: > 26000 nM
Compound 4 ended at the assay's limit; the forecaster's own chance of this, stated with the estimate: 85%; the middle value does not contradict the limit.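

No size can be read for the change from compound 2 to compound 4, because both give only a limit: the limit of > 26000 nM in this assay, at which 4 of the 4 values shown sit.

The compounds shown leave open whether formyl and (propylamino)methyl differ at all in this assay, since none gives an actual number there.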